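Swapping an Aryl Amine for a Benzyl Amine

The source may report more compounds than this note shows. Statements on the series, on what has been measured and on what is new or still open speak of the compounds shown alone.

Measured compounds:
compound 1 `O=C(C1=C(OC2CCCCC2)C(=O)N(CCCn2ccnc2)C1c1ccc(Br)cc1)c1ccccc1`: 22400 nM
compound 2 `CCOc1ccc(NC2=C(C(=O)c3ccccc3)C(c3ccc(Br)cc3)N(CCCn3ccnc3)C2=O)cc1`: 26200 nM

Both numbers come from a functional assay on U2OS cells (Homo sapiens) for antiproliferative activity, read by MTT assay, with a stated time of 72 h; a lower number here means a stronger inhibitor, a higher number a weaker inhibitor. Compound 2 holds the higher of the two numbers, but its nearest neighbour, compound 1, sits within the scatter of it, so the two cannot be told apart. Among the compounds with values here, the one measured step, a 1.2-fold higher number from compound 1 to compound 2 (0.07 log units; within the scatter), replaced the group on the double-bonded ring carbon and left the number essentially where it was. Compound 3 `O=C(C1=C(NCc2ccccc2)C(=O)N(CCCn2ccnc2)C1c1ccc(Br)cc1)c1ccccc1` alters that same position once more: benzyl in place of 4-ethoxyphenyl on an amine nitrogen. Within the data shown here, the only step that speaks to this place lay within the scatter, so a further change there is expected to move the number little and in no clear direction. Compound 3 is therefore estimated at 25000 nM in this assay, with a range of 9000 nM to 70000 nM. The expected step is a 1.0-fold lower number from compound 2 to compound 3 (0.02 log units; within the scatter), within the scatter.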

Compound 3, half-maximal inhibitory concentration: 32500 nM
The estimate for compound 3 lay 1.3-fold (0.11 log units) below the measured number, and the stated range covers the measured number.
By their numbers in this assay, from the lowest: compounds 1, 2 and 3 (each within the scatter of the next).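

In this assay the swap to benzyl gives a 1.2-fold higher number from compound 2 to compound 3 (0.09 log units; within the scatter) and so the two groups on the amine nitrogen cannot be told apart, even though benzyl carries fewer heavy atoms than 4-ethoxyphenyl and no hydrogen-bond acceptor. Replacing cyclohexyloxy with benzylamino on the double-bonded ring carbon gives a 1.5-fold higher number from compound 1 to compound 3 (0.16 log units; within the scatter) and so all three groups seen at this place remain indistinguishable in this read-out. No measured evidence accompanies this flat result.

On these data alone, what stays open is whether any group at this place can move the number beyond the scatter at all. A simple amine, a carboxylic acid or a longer alkyl chain on the double-bonded ring carbon would put that question to the test, while the compounds shown say nothing about the rest of the shared core.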